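This account rests on a few compounds, and the source may have more. Where it says the series, first, only, none or still open, it means among the compounds named here.

Three compounds have been measured in a functional assay for agonist activity at G protein-coupled receptor 88 (Homo sapiens), read by HTRF and cAMP accumulation; a lower number here means that less compound is needed, a higher number that more compound is needed for the effect:
compound 1 `CC[C@H](C)[C@H](N)CN(C(=O)[C@@H]1C[C@H]1c1ccccc1F)c1ccc(-c2ccccc2)cc1` gives 650 nM;
compound 2 `CC[C@H](C)[C@H](N)CN(C(=O)[C@@H]1C[C@H]1c1c(F)cccc1F)c1ccc(-c2ccccc2)cc1` gives 11000 nM;
compound 3 `CC[C@H](C)[C@H](N)CN(C(=O)[C@@H]1C[C@H]1c1ccccn1)c1ccc(-c2ccccc2)cc1` gives 130 nM.

Compound 3 stands lowest of the three numbers. Its nearest neighbour is compound 1, separated by the step of a 5.0-fold lower number from compound 1 to compound 3 (0.70 log units; beyond the scatter), and its furthest is compound 2, separated by an 85-fold lower number from compound 2 to compound 3 (1.93 log units; beyond the scatter).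

The next compound, compound 4 `CC[C@H](C)[C@H](N)CN(C(=O)[C@@H]1C[C@H]1c1ncc(C)s1)c1ccc(-c2ccccc2)cc1`, differs from compound 3 in a single place: 5-methyl-1,3-thiazol-2-yl in place of pyridin-2-yl on a saturated ring carbon.

Going by the values given here, no measured step exchanges one aromatic ring for another of a different kind. The step of a 17-fold higher number from compound 1 to compound 2 (1.23 log units; beyond the scatter) concerns fluoro in place of hydrogen, while a 5.0-fold lower number from compound 1 to compound 3 (0.70 log units; beyond the scatter) and an 85-fold lower number from compound 2 to compound 3 (1.93 log units; beyond the scatter) show that pyridin-2-yl gave lower numbers than the two fluorophenyl groups it replaced. Among the compounds with values here, both the leaving and the entering group are small aromatic rings carrying hydrogen-bond acceptors, and with no step of this kind on record, only a modest shift in this assay is expected: the estimated step of a 1.9-fold higher number from compound 3 to compound 4 (0.28 log units; within the scatter) points slightly toward a higher number. Compound 4 is estimated at 250 nM, with a range from 80 nM to 800 nM.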

Compound 4, half-maximal effective concentration: 1300 nM
Estimate against measurement, compound 4: 5.2-fold (0.72 log units) below, outside the stated range (above it).
By their numbers in this assay, from the lowest: compound 3; then compounds 1 and 4 (each within the scatter of the next); then compound 2.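

Going by these compounds alone, at this saturated ring carbon in this assay, the earlier compounds carried only six-membered aromatic rings; the five-membered 5-methyl-1,3-thiazol-2-yl ring now shows that the low number seen with pyridin-2-yl does not carry over to every small ring with a ring nitrogen, with a 10-fold higher number from compound 3 to compound 4 (1.00 log units; beyond the scatter) for this exchange. The new ring still compares well with 2,6-difluorophenyl, with an 8.5-fold lower number from compound 2 to compound 4 (0.93 log units; beyond the scatter) on that exchange, whereas a 2.0-fold higher number from compound 1 to compound 4 (0.30 log units; within the scatter) leaves it indistinguishable from 2-fluorophenyl. The data at hand offer no explanation for these differences.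

This exchange alters the ring size, the hetero atoms and the methyl group all at once, and the compounds shown cannot separate those changes. A plain 1,3-thiazol-2-yl ring without the methyl would isolate the methyl's contribution, and a pyrimidin-2-yl ring would test a second ring nitrogen.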